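Indole vinyl sulfones: removing the methoxy from compound 2

The compounds below may be only part of what the source reports. "The series", "measured", "known", "first", "only" and "open" are said of these compounds alone.

Two members of the series carry a measured value. Compound 1 `CC(=O)/C(=C\c1c(-c2ccccc2)[nH]c2ccccc12)S(=O)(=O)c1ccccc1` is the acetyl-bearing analogue on the unsubstituted core; in a functional assay on OVCAR-3 cells (Homo sapiens) for inhibition, read by sulforhodamine B assay, with a stated time of 48 h (on this read-out higher numbers stand for weaker inhibition of growth and lower numbers for stronger inhibition of growth), compound 1 gives 1600 nM. Compound 2 `COc1ccc2[nH]c(-c3ccccc3)c(/C=C(\C#N)S(=O)(=O)c3ccccc3)c2c1` pairs the nitrile with a methoxy-substituted core; in this assay compound 2 gives 5000 nM, the highest of the two numbers, and its gap to compound 1 lies beyond the scatter. For the measured compounds named here, compounds 1 and 2 differ in two places, so no single step between them can be read from their values.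

Compound 3 `N#C/C(=C\c1c(-c2ccccc2)[nH]c2ccccc12)S(=O)(=O)c1ccccc1` is the next candidate. The change from compound 2 is hydrogen in place of methoxy on an aromatic carbon, which brings the core into line with that of compound 1 while keeping the nitrile. The step from compound 2 to compound 3 is expected to be modest, toward a lower number, as a 1.7-fold lower number from compound 2 to compound 3 (0.22 log units; within the scatter), since compound 1 on the same core gives 1600 nM. Compound 3 is estimated at 3000 nM, within 900 nM to 10000 nM.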

Compound 3, concentration for 50% growth inhibition: 1400 nM
Estimate against measurement, compound 3: 2.1-fold (0.33 log units) above, and the stated range covers the measured number.
By their numbers in this assay, from the lowest: compounds 3 and 1 (each within the scatter of the next); then compound 2.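

In this assay the methoxy position now has a readable step: hydrogen in place of methoxy on an aromatic carbon gives a 3.6-fold lower number from compound 2 to compound 3 (0.55 log units; beyond the scatter) and so, in this nitrile-bearing pair, the methoxy goes with weaker inhibition of growth. The chain position also becomes readable: cyano in place of acetyl on a double-bonded chain carbon gives a 1.1-fold lower number from compound 1 to compound 3 (0.06 log units; within the scatter) and so, on the shared core without methoxy, the two groups cannot be told apart on this read-out. Nothing at hand explains the size of the methoxy step.

As far as these compounds go, whether the methoxy step holds with acetyl in place of the nitrile stays open, as it rests on a single pair. Also open, from the compounds shown here alone, is how fluorine or an amine on the same aromatic carbon, or a carboxylic acid in place of the nitrile, would read.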